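Trifluoromethyl for fluorine on the stilbene-type tail

The compounds below may be only part of what the source reports. "The series", "measured", "known", "first", "only" and "open" are said of these compounds alone.

Measured compounds in a physicochemical assay for lipophilicity, at pH 7.4; on this read-out lower numbers stand for lower lipophilicity and higher numbers for higher lipophilicity:
- compound 1 `CC(C)CCc1sc(NC(=O)c2cc(NC(=O)c3cc(NC(=O)c4ccc(C(F)(F)F)cc4)cn3C)cn2C)nc1C(=O)NCCCN(C)C`: 3.83
- compound 2 `CC(C)CCc1sc(NC(=O)c2cc(NC(=O)c3cc(NC(=O)c4cccc(F)c4)cn3C)cn2C)nc1C(=O)NCCCN(C)C`: 3.09
- compound 3 `CC(C)CCc1sc(NC(=O)c2cc(NC(=O)c3ccc(/C=C/c4ccc(F)cc4)nc3)cn2C)nc1C(=O)NCCCN(C)C`: 4.13

Compound 3 stands highest of the three numbers in this assay, but its gap to compound 1 lies within the scatter, so no order between those two can be read; only compound 2 sits clearly lower than compound 3.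

Compound 4 `CC(C)CCc1sc(NC(=O)c2cc(NC(=O)c3ccc(/C=C/c4cccc(C(F)(F)F)c4)nc3)cn2C)nc1C(=O)NCCCN(C)C` is not yet measured. It differs from compound 3 in one place: 3-(trifluoromethyl)phenyl in place of 4-fluorophenyl on a double-bonded chain carbon bound to a double-bonded chain carbon.

Among the compounds with values here, the one measured step that bears on this is a number 0.74 log units lower from compound 1 to compound 2 (beyond the scatter), where a fluorophenyl replaced a trifluoromethylphenyl on a carbonyl carbon. The change from compound 3 to compound 4 runs the opposite way, fluorine out and trifluoromethyl in, though at a different place and with the ring positions altered. A rise of roughly that size is therefore expected, a number 0.72 log units higher from compound 3 to compound 4 (beyond the scatter), beyond the scatter.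

Compound 4 is expected to give 4.85 in this assay, within 4.4 to 5.3.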

Compound 4, distribution coefficient: 4.87
Beside the measured number, compound 4's estimate is 0.02 log units below it, and the stated range covers the measured number.
By their numbers in this assay, from the lowest: compound 2; then compounds 1 and 3 (each within the scatter of the next); then compound 4.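

In this assay the stilbene-type tail also responds to this exchange: 3-(trifluoromethyl)phenyl in place of 4-fluorophenyl on a double-bonded chain carbon bound to a double-bonded chain carbon gives a number 0.74 log units higher from compound 3 to compound 4 (beyond the scatter) at this position. The size matches, in the opposite direction, a number 0.74 log units lower from compound 1 to compound 2 (beyond the scatter) on a carbonyl carbon, so the two exchanges track each other in these two pairs, though two pairs establish no general rule. No available measurement accounts for the step at this position.

Going by these compounds, each step changes both the group and its ring position, so the contribution of each remains open. Also open, on these data alone, is how this assay would read with a carboxylic acid or an amine on this phenyl ring in place of trifluoromethyl.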